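Trimethoxyphenyl in Place of Piperidin-1-yl on the Shared Core

A few compounds are considered here, and "the series" means these few. Any claim that something is new, unique, unknown or untested is made for them only; others in the source may bear on it.

Of the compounds shown here, three built on one shared core have been measured in a functional assay on HCC78 cells (Homo sapiens) for antiproliferative activity, read by MTT assay, with a stated time of 48 h; on this read-out lower numbers stand for stronger inhibition and higher numbers for weaker inhibition. Compound 1 `Cc1ccc(CNC(=O)c2cccc(C(C)Oc3ccnc(Nc4cnn(C5CCN(C)CC5)c4)c3)c2)cc1` gives 8100 nM, compound 2 `Cc1ccc(CNC(=O)c2cccc(C(C)Oc3ccnc(NN4CCOCC4)c3)c2)cc1` gives 68300 nM, and compound 3 `Cc1ccc(CNC(=O)c2cccc(C(C)Oc3ccnc(NN4CCCCC4)c3)c2)cc1` gives 24500 nM. Compound 3 stands second highest of the three numbers: its nearest neighbour is compound 2, reached through the step of a 2.8-fold lower number from compound 2 to compound 3 (0.45 log units; beyond the scatter), and its furthest is compound 1, reached through the step of a 3.0-fold higher number from compound 1 to compound 3 (0.48 log units; beyond the scatter). The largest step among them is an 8.4-fold higher number from compound 1 to compound 2 (0.93 log units; beyond the scatter).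

Compound 4 `COc1cc(Nc2cc(OC(C)c3cccc(C(=O)NCc4ccc(C)cc4)c3)ccn2)cc(OC)c1OC` differs from compound 3 in one place: 3,4,5-trimethoxyphenyl in place of piperidin-1-yl on a nitrogen on an aromatic ring. Within the data shown here, no measured step exchanges piperidin-1-yl for an aromatic ring of carbon only, so the steps that bear on it are those between a group containing an aromatic ring and a six-membered non-aromatic ring on the same nitrogen, namely a 3.0-fold higher number from compound 1 to compound 3 (0.48 log units; beyond the scatter) and an 8.4-fold higher number from compound 1 to compound 2 (0.93 log units; beyond the scatter). Both steps were modest and pointed toward a higher number on going from aromatic to non-aromatic, so the reverse direction is expected here. Compound 4 is therefore expected to show a lower number than compound 3, by about a 6.1-fold lower number from compound 3 to compound 4 (0.79 log units; beyond the scatter). The estimate for compound 4 in this assay is 4000 nM, within a range of 800 nM to 20000 nM.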

Compound 4, half-maximal inhibitory concentration: 15700 nM
For compound 4 the middle estimate is 3.9-fold (0.59 log units) below the measured one; measured number inside the range.
By their numbers in this assay, from the lowest: compounds 1, 4 and 3 (each within the scatter of the next, the first and the last beyond it); then compound 2.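

In this assay, the change to 3,4,5-trimethoxyphenyl on a nitrogen on an aromatic ring gives a 1.6-fold lower number from compound 3 to compound 4 (0.19 log units; within the scatter), so an aromatic ring of carbon only, with 12 heavy atoms in place of 6, cannot be told apart from piperidin-1-yl at this position. The earlier compounds shown here offered only the pyrazole-bearing group of compound 1 as an aromatic example, and the new compound cannot be told apart from it either, at a 1.9-fold higher number from compound 1 to compound 4 (0.29 log units; within the scatter), which shows that an aromatic ring on this nitrogen does not by itself set the number, since compound 1 and compound 3 do stand apart while compound 4 lies within the scatter of both. The one clear separation is from morpholin-4-yl, at a 4.4-fold lower number from compound 2 to compound 4 (0.64 log units; beyond the scatter), which leaves compound 2 as the weakest of the four, with its steps to all three others beyond the scatter.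

No measurement shown here explains why any of these groups reads as it does. Going by these compounds, it remains open whether the three methoxy groups matter at all, which a plain phenyl on the same nitrogen would test, and whether a phenyl carrying a 4-methylpiperazin-1-yl group would behave like compound 1 or compound 4.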